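Bromo to fluoro: one small swap, three measured compounds

The source may hold more compounds than are shown below. What is called first, only, known or untested is meant among the compounds shown, and "the series" means these compounds.

The measured set in an ADME assay on cells (Macrophage, Mus musculus) for cytotoxicity, read by resazurin assay, with a stated time of 3 days (a higher number here means a weaker inhibitor, a lower number a stronger inhibitor), is as follows:
Compound 1, `O=C(Nc1ccc(F)cc1C(F)(F)F)c1cc(Cl)ccc1O`, gives 13000 nM.
Compound 2, `O=C(Nc1ccc(Br)cc1C(F)(F)F)c1cc(Cl)ccc1O`, gives 11000 nM.
Compound 3, `O=C(Nc1cc(F)c(Br)c(F)c1)c1cc(Cl)ccc1O`, gives 4300 nM.

Compound 4, `O=C(Nc1cc(F)c(F)c(F)c1)c1cc(Cl)ccc1O`, has not yet been measured. It differs from compound 3 in one spot: fluoro in place of bromo on an aromatic carbon. The same kind of change links compound 2 to compound 1: fluoro in place of bromo on an aromatic carbon. The surroundings are not identical, though: in compound 1 the new fluoro sits meta to a trifluoromethyl group, while in compound 4 it sits ortho to two fluoro groups. How the cores of compound 2 and compound 3 differ is not broken down here. The earlier swap gave a 1.2-fold higher number from compound 2 to compound 1 (0.07 log units; within the scatter). A similarly small step is expected for compound 4, a 1.3-fold higher number from compound 3 to compound 4 (0.11 log units; within the scatter), because the matching change gave a 1.2-fold higher number from compound 2 to compound 1 (0.07 log units; within the scatter). Compound 4 is therefore estimated at 5500 nM in this assay, most likely between 2500 nM and 12000 nM.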

Compound 4, half-maximal inhibitory concentration: 4700 nM
Compound 4: the middle estimate sits 1.2-fold (0.07 log units) above what was measured; the range from low to high includes it.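

In this assay, fluoro in place of bromo on an aromatic carbon gives a 1.1-fold higher number from compound 3 to compound 4 (0.04 log units; within the scatter) and so leaves no difference that can be told apart from ordinary repeat-to-repeat variation. The swap therefore behaved alike on the two cores shown: the same change on two cores in this assay, a 1.2-fold higher number (0.07 log units; within the scatter) from compound 2 to compound 1 and a 1.1-fold higher number (0.04 log units; within the scatter) from compound 3 to compound 4, 1.1-fold (0.03 log units) apart, within the scatter of two such steps

Among these compounds, this agreement rests on only two pairs of compounds, and both steps are small, so it does not show that the swap would stay this quiet on other cores or in other assays. It also gives no explanation for the result.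

The compounds shown leave open what other groups at this place on the ring, such as an amine, a carboxylic acid or a longer chain, would do in this assay.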